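A few compounds are considered here, and "the series" means these few. Any claim that something is new, unique, unknown or untested is made for them only; others in the source may bear on it.

Working notes on the series.

For the measured compounds named here, in a functional assay on blood for antagonist activity at thromboxane A2 receptor (Homo sapiens) (on this read-out lower numbers stand for tighter binding and higher numbers for weaker binding), compound 1 `CS(=O)(=O)Nc1cccc(-c2ccc(COC3CC[C@H](N4CCCCCC4)[C@H]3OC/C=C\CCC(=O)O)cc2)c1` gives 12.6 nM, the lowest of the two single numbers so far; the nearest single number is that of compound 3 `O=C(O)CC/C=C\CO[C@@H]1C(OCc2ccc(-c3ccccc3)cc2)CC[C@@H]1N1CCCCC1`, which gives 39.8 nM, a gap beyond the scatter. Compound 2 `O=C(O)CC/C=C\CO[C@H]1[C@@H](OCc2ccc(-c3ccccc3)cc2)CC[C@@H]1N1CCCCC1` has no single number but several entries, 10 nM; 7.94 nM (2 entries), as noted in the several entries of compound 2 in this assay, 10 nM; 7.94 nM (2 entries). Compound 3 is drawn without a defined configuration where compound 2 has one (the fact that one of compounds 2 and 3 is drawn with a defined configuration and the other without, at the place where they differ); their numbers differ, nothing more can be said of that pair.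

Compound 4 `CS(=O)(=O)Nc1ccccc1-c1ccc(COC2CC[C@H](N3CCCCCC3)[C@H]2OC/C=C\CCC(=O)O)cc1` differs from compound 1 by 2-(methanesulfonamido)phenyl in place of 3-(methanesulfonamido)phenyl on an aromatic carbon. Going by the values given here, no step of this kind has been measured. In this assay a modest step toward a higher number is expected, a 2.0-fold higher number from compound 1 to compound 4 (0.30 log units; within the scatter), plausibly beyond the scatter but not large. Compound 4 is estimated at 25 nM, within 6 nM to 100 nM.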

Compound 4, dissociation constant: 10 nM
For compound 4 the middle estimate is 2.5-fold (0.40 log units) above the measured one; the range from low to high includes it.
By their numbers in this assay, from the lowest: compounds 4 and 1 (each within the scatter of the next); then compound 3.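

In this assay, 2-(methanesulfonamido)phenyl in place of 3-(methanesulfonamido)phenyl gives a 1.3-fold lower number from compound 1 to compound 4 (0.10 log units; within the scatter), the first step read at this position of the series. The two placements of the methanesulfonamido group are therefore not told apart in this read-out. Nothing on record bears on the reason for this step.

Still open, from the compounds shown here alone, is how a carboxylic acid or an amine in place of the methanesulfonamido group would read against compound 1. Also open, going by these compounds, is whether the two placements stay level when the rest of the core of compound 1 is changed.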